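The source may report more compounds than this note shows. Statements on the series, on what has been measured and on what is new or still open speak of the compounds shown alone.

Compound 1 `CNC(=O)N1CCCc2ccc(NC(=O)c3cccc(-c4ccn(C)n4)c3)cc21` in a functional assay on MV4-11 cells (Homo sapiens) for antiproliferative activity, with a stated time of 6 days, tested at 6.25 uM (on this read-out higher numbers stand for a stronger effect at the one concentration tested and lower numbers for a weaker effect), gives 99.5%. Compound 2 `CNC(=O)N1CCCc2ccc(NC(=O)c3cccc(-c4ccn(S(C)(=O)=O)n4)c3)cc21` in this assay gives 37%, and compound 3 `CNC(=O)N1CCCc2ccc(NC(=O)c3ccc(-c4ccn(C(C)=O)n4)cc3)cc21` gives 91.4%. Compound 2 thus stands lowest of the three numbers, with compound 3 the nearer and compound 1 the further of the two higher values. Within the data shown here, the one measured step that bears on the next change is a number 62.5 percentage points lower from compound 1 to compound 2 (beyond the scatter), a large drop beyond the scatter.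

Compound 4 `CNC(=O)N1CCCc2ccc(NC(=O)c3cccc(-c4ccn(C(C)=O)n4)c3)cc21` differs from compound 2 by acetyl in place of methylsulfonyl on an aromatic nitrogen. Among the measured compounds shown here, the acetyl group on the aromatic nitrogen also occurs in compound 3, whose high value sits close to that of compound 1; no single-change step joins compound 3 to compound 2 or compound 4, so only the two values themselves can be read. Since the methylsulfonyl group is what set compound 2 apart in the step from compound 1, removing it is expected to restore much of the effect: the estimated step is a number 48 percentage points higher from compound 2 to compound 4 (beyond the scatter), upward and beyond the scatter. Compound 4 is expected to give 85%, within 55% to 99%.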

Compound 4, a percentage reported as inhibition, at one concentration (the size of the read-out at that concentration, not a potency): 87.6%
For compound 4 the middle estimate is 2.6 percentage points below the measured one, and the stated range covers the measured number.
By their numbers in this assay, from the lowest: compound 2; then compounds 4, 3 and 1 (each within the scatter of the next, the first and the last beyond it).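

Replacing methylsulfonyl with acetyl on the aromatic nitrogen gives a number 50.6 percentage points higher from compound 2 to compound 4 (beyond the scatter), so a group other than methyl at this position need not bring the number in this assay down to the level of compound 2. Acetyl still does not fully match methyl here, giving a number 11.9 percentage points lower from compound 1 to compound 4 (beyond the scatter), a much smaller loss than a number 62.5 percentage points lower from compound 1 to compound 2 (beyond the scatter). Nothing available explains the difference between these groups on the nitrogen.

Open questions are how a longer acyl chain, such as propanoyl, or a substituent bearing an amine or a carboxylic acid would behave at this nitrogen. These single-concentration numbers also leave open how far the potencies of compound 1, compound 2 and compound 4 differ.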